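Nitrophenyl-piperazine series: pyrrolyl in place of fluorobenzyl

The source may report more compounds than this note shows. Statements on the series, on what has been measured and on what is new or still open speak of the compounds shown alone.

Working notes on a small set of aryl-piperazines read in an assay on HEK293 cells for displacement of a labelled ligand from 5-hydroxytryptamine receptor 6 (Homo sapiens); a lower number here means a stronger inhibitor, a higher number a weaker inhibitor. Compound 1 `CN1CCN(c2ccc([N+](=O)[O-])c(NCc3ccc(F)cc3)c2)CC1` gives 172 nM in this assay. Among the three numbers in hand it is the second highest. Compound 2 `O=[N+]([O-])c1ccc(N2CCNCC2)cc1NCCOc1ccccc1` gives 114 nM in this assay, a number within the scatter of that of compound 1, so no order between the two is claimed. Compound 3 `CN1CCN(c2ccc(OCc3ccccc3)c(NCc3ccco3)c2)CC1` gives 402 nM in this assay, a number beyond the scatter above that of compound 1. No pair of these compounds differs in only one place, so no single-point step is available.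

The next compound, compound 4 `CN1CCN(c2ccc([N+](=O)[O-])c(Nn3cccc3)c2)CC1`, has not been measured. Relative to compound 1 it carries the change (1H-pyrrol-1-yl in place of 4-fluorobenzyl on a nitrogen on an aromatic ring). Among the compounds with values here, the group that leaves is the larger one, and the group that enters sits directly on the nitrogen rather than through a one-carbon link; no measured pair in this set tests such a change. The step is expected to be toward a higher number in this assay, beyond the scatter, as expressed by a 3.8-fold higher number from compound 1 to compound 4 (0.58 log units; beyond the scatter). Compound 4 is accordingly estimated at 650 nM in this assay, with a range from 220 nM to 2000 nM.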

Compound 4, inhibition constant: 481 nM
The estimate for compound 4 lay 1.4-fold (0.13 log units) above the measured number, within the range that was stated.
By their numbers in this assay, from the lowest: compounds 2 and 1 (each within the scatter of the next); then compounds 3 and 4 (each within the scatter of the next).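

In this assay, within the data shown here, 1H-pyrrol-1-yl in place of 4-fluorobenzyl on a nitrogen on an aromatic ring gives a 2.8-fold higher number from compound 1 to compound 4 (0.45 log units; beyond the scatter), the only single-point step in this set, so the number at this position does depend on the group carried there, although the step is modest. The change is not a single variable: a group of 8 heavy atoms with a six-membered aromatic ring of carbon only gives way to one of 5 heavy atoms with a five-membered aromatic ring holding 1 hetero atom, and the one-carbon link is lost as well, so the step cannot be divided among these differences. No measurement that would explain the step is at hand.

The compounds shown leave open how much of the step follows the one-carbon link and how much follows the ring itself; a pyrrol-1-ylmethyl group or an unsubstituted benzyl on the same nitrogen would separate these two differences. Also open, as far as these compounds go, is how a longer chain, such as 2-phenylethyl, or an open-chain group such as a 2-aminoethyl would read at this position.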